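Adding a 4-Fluorophenyl Group and Expected Microsomal Stability

The source may hold more compounds than are shown below. What is called first, only, known or untested is meant among the compounds shown, and "the series" means these compounds.

Compound 1 `C[C@H](Nc1nc(N)nc(N)c1C#N)c1cc2ccc(F)cn2c(=O)c1-c1ccccc1` is the most stable of three compounds in an ADME assay on microsomes from liver (Rattus norvegicus), read by LC-MS, using NADPH, with a stated time of 30 min, tested at 1 uM (on this read-out lower numbers stand for a less stable compound and higher numbers for a more stable compound), where compound 1 gives 88%. Compound 2 `C[C@H](Nc1nc(N)ncc1C#N)c1cc2ccc(F)cn2c(=O)c1-c1ccccc1` gives 74% in this assay, and compound 3 `Cc1cccc(-c2c([C@H](C)Nc3nc(N)nc(N)c3C#N)cc3ccc(F)cn3c2=O)c1` gives 77%. Two steps away from compound 1 have been measured: the step of a number 14 percentage points lower from compound 1 to compound 2 (beyond the scatter) and the step of a number 11 percentage points lower from compound 1 to compound 3 (beyond the scatter). Each shows that a small change to compound 1 costs some stability.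

Compound 4 `C[C@H](Nc1nc(N)nc(N)c1C#N)c1c(-c2ccccc2)c(=O)n2cc(F)ccc2c1-c1ccc(F)cc1` has not yet been measured. It differs from compound 1 by 4-fluorophenyl in place of hydrogen on an aromatic carbon, the new group entering on an aromatic carbon of the shared core. Neither measured step adds a group of this kind, so both bear on the new change only loosely; the step from compound 1 to compound 3, which also places a carbon group on an aromatic carbon, is the nearer comparison. Because a number 11 percentage points lower from compound 1 to compound 3 (beyond the scatter) and a number 14 percentage points lower from compound 1 to compound 2 (beyond the scatter) both went down, a modest fall is expected here as well. The estimated step is a number 13 percentage points lower from compound 1 to compound 4 (beyond the scatter). Compound 4 is thus expected to give about 75% in this assay, with a likely range from 55% to 90%.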

Compound 4, percent of the compound remaining in the Rattus norvegicus assay: 77%
Beside the measured number, compound 4's estimate is 2 percentage points below it; the measured number falls inside the stated range.
By their numbers in the Rattus norvegicus assay, from the lowest: compounds 2, 3 and 4 (each within the scatter of the next); then compound 1.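

The earlier steps shown here changed only a small group, whereas this one shows that an aromatic carbon of the shared core, two atoms from the ring nitrogen, can carry a whole new ring. In the Rattus norvegicus assay that larger change gives a number 11 percentage points lower from compound 1 to compound 4 (beyond the scatter), a modest step that leaves compound 4 with much of its parent's stability. In a physicochemical assay for solubility (a higher number here means a more soluble compound, a lower number a less soluble compound), compound 1 gives 691000 nM and compound 4 gives 68500 nM and this adds what the earlier compounds could not show, that the same change has a clear cost outside stability, with a drop that is also beyond the scatter: the measured solubility of compound 1, 691000 nM, and of compound 4, 68500 nM, a 10-fold lower number (1.00 log units; beyond the scatter)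

The compounds shown leave open whether a smaller or differently built group on this carbon, such as methyl, an amine or a carboxylic acid, would keep the stability while giving up less solubility. They also leave open what the fluorine of the new group contributes, a question that a plain phenyl group on this same carbon would help to answer.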